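The source may hold more compounds than are shown below. What is called first, only, known or untested is meant among the compounds shown, and "the series" means these compounds.

Measured compounds:
compound 1 `COC(=O)C1=C(C)N=C(C)/C(=C(\O)OC)C1c1ccccc1N` — 39800 nM
compound 2 `COC(=O)C1=C(C)N=C(C)/C(=C(\O)OC)C1c1cccc(I)c1` — 41.7 nM
compound 3 `CCOc1ccccc1C1C(C(=O)OC)=C(C)N=C(C)/C1=C(\O)OC` — 110 nM

All three were tested in a functional assay (muscle tissue) with Cavia porcellus as the target; a higher number here means that more compound is needed for the effect, a lower number that less compound is needed. Compound 2 gives the lowest of the three numbers; compound 3 stands nearest to it, compound 1 furthest. The two recorded steps both start from compound 1: a 950-fold lower number from compound 1 to compound 2 (2.98 log units; beyond the scatter) for the change to compound 2, and a 360-fold lower number from compound 1 to compound 3 (2.56 log units; beyond the scatter) for the change to compound 3.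

Compound 4 `COC(=O)C1=C(C)N=C(C)/C(=C(\O)OC)C1c1cccc(F)c1` is not yet measured. It differs from compound 2 in one place: fluoro in place of iodo on an aromatic carbon. Neither recorded step exchanges one halogen for another on the same aromatic carbon; the step from compound 1 to compound 2 changes both the group and its place, so it does not speak directly to this swap. Within the data shown here, the only guidance is that the shared core with an unsubstituted-by-polar-group aryl ring keeps a low number in this assay, seen for compound 2 and compound 3. A moderate rise in the number is expected, a 3.6-fold higher number from compound 2 to compound 4 (0.56 log units; beyond the scatter), since nothing in the data shows iodo to be readily replaced without loss. Compound 4 is therefore estimated at 150 nM, with a range from 40 nM to 600 nM.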

Compound 4, half-maximal effective concentration: 20.9 nM
For compound 4 the middle estimate is 7.2-fold (0.86 log units) above the measured one; measured number outside the range, below it.
By their numbers in this assay, from the lowest: compounds 4 and 2 (each within the scatter of the next); then compound 3; then compound 1.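

In this assay, fluoro in place of iodo on this aromatic carbon, meta to a large group, gives a 2.0-fold lower number from compound 2 to compound 4 (0.30 log units; within the scatter), so the two halogens cannot be told apart at this position and iodine is not required for a low number. The large gap from the aminophenyl compound also holds with the smaller halogen, at a 1900-fold lower number from compound 1 to compound 4 (3.28 log units; beyond the scatter), which shows that this gap does not depend on iodine. No measurement at hand offers an explanation for either result.

Open, from the compounds shown here alone, is whether a group of another kind on this carbon, such as nitro, methoxy or a carboxylic acid, keeps the number as low as the two halogens do. Also open, going by these compounds, is what amino on this same carbon would give, as compound 1 differs from compound 4 in both the group and its place.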